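Swapping Bromo for Methoxy on Compound 3

This account rests on a few compounds, and the source may have more. Where it says the series, first, only, none or still open, it means among the compounds named here.

In a functional assay on P388 cells (Mus musculus) for inhibition (a higher number here means a weaker inhibitor, a lower number a stronger inhibitor), compound 1 (`COc1cccc(/C=C2\CCCc3ccccc3C2=O)c1OC`) gives 8580 nM and compound 2 (`O=C1/C(=C/c2ccc(Cl)c(Cl)c2)CCCc2ccccc21`) gives 12200 nM while compound 3 (`O=C1/C(=C/c2ccccc2Br)CCCc2ccccc21`) gives 19800 nM as its reading. Compound 3 thus has a higher number than compound 1 by more than the usual scatter, yet lies within the scatter of compound 2. Compound 4 (`COc1ccccc1/C=C1\CCCc2ccccc2C1=O`) has methoxy in place of bromo on an aromatic carbon. Among the measured compounds shown here, no measured pair shows this swap alone. Compound 1 also carries methoxy and gives 8580 nM in the same test, so a small drop, perhaps none beyond the scatter, is expected in this assay for this swap. The estimated step is a 1.7-fold lower number from compound 3 to compound 4 (0.22 log units; within the scatter) at its middle. For compound 4 the estimated value is 12000 nM with a range from 5000 nM to 28000 nM overall.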

Compound 4, half-maximal inhibitory concentration: 18000 nM
Estimate against measurement, compound 4: 1.5-fold (0.18 log units) below; measured number inside the range.
By their numbers in this assay, from the lowest: compounds 1, 2, 4 and 3 (each within the scatter of the next, the first and the last beyond it).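

In this assay, methoxy in place of bromo on an aromatic carbon, ortho to a large group, gives a 1.1-fold lower number from compound 3 to compound 4 (0.04 log units; within the scatter), so this swap does not separate the two groups here. Hydrogen in place of one methoxy, by contrast, gives a 2.1-fold higher number from compound 1 to compound 4 (0.32 log units; beyond the scatter), a modest step but one beyond the scatter. Nothing measured here explains either step. As far as these compounds go, whether an amine or a carboxylic acid on this same carbon would move the number stays open.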